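This account rests on a few compounds, and the source may have more. Where it says the series, first, only, none or still open, it means among the compounds named here.

Measured compounds in an assay on CHO cells for displacement of a labelled ligand from adenosine receptor A3 (Homo sapiens); a higher number here means a weaker inhibitor, a lower number a stronger inhibitor:

Compound 1 `CCNC(=O)[C@H]1O[C@@H](n2cnc3c(NNC(=O)c4ccccc4)ncnc32)[C@H](O)[C@@H]1O` gives > 5000 nM, which is a limit of the assay and not a number.
Compound 2 `CCNC(=O)[C@H]1O[C@@H](n2cnc3c(NNC(=O)c4cccnc4)ncnc32)[C@H](O)[C@@H]1O` gives > 5000 nM, likewise a limit.
Compound 3 `CCNC(=O)[C@H]1O[C@@H](n2cnc3c(NNC(=O)c4ccccc4)nc(Cl)nc32)[C@H](O)[C@@H]1O` gives > 5000 nM, again a limit.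

Compound 3 thus stands only at a limit in this assay, and the two further values shown are limits as well, so that all three sit at the limit of > 5000 nM in this assay, at which 3 of the 3 values shown sit. The step from compound 1 to compound 2, a step that the two limits leave unreadable from compound 1 to compound 2, and the step from compound 1 to compound 3, a step that the two limits leave unreadable from compound 1 to compound 3, are both left unreadable in size by the limits at either end. Nothing in the measured set gives a readable direction or magnitude for any change on the carbonyl carbon or on the aromatic carbon.

Compound 4 `CCNC(=O)[C@H]1O[C@@H](n2cnc3c(NNC(=O)c4ccc[nH]4)nc(Cl)nc32)[C@H](O)[C@@H]1O` differs from compound 3 by 1H-pyrrol-2-yl in place of phenyl on a carbonyl carbon. For the measured compounds named here, the only measured step that touches the same place, from compound 1 to compound 2, replaced phenyl by a six-membered heteroaromatic ring and left the value at the limit; the present change brings in a five-membered ring with one hydrogen-bond donor instead. With no readable step to lean on, compound 4 is expected to remain at the limit, and the step from compound 3 to compound 4 is estimated as a step that the limit leaves unreadable from compound 3 to compound 4, that is, none that can be told from the scatter. For compound 4 in this assay the estimate is 8000 nM, with a range from 3000 nM to 30000 nM.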

Compound 4, inhibition constant: > 5000 nM
Compound 4 was reported as a limit; the forecaster's own chance of this, stated with the estimate: 85%; the middle value is on the limit's open side.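

In this assay compound 4 gives > 5000 nM, a limit and not a number, so the change from compound 3 to compound 4 yields no readable step. The series stays at a single limit: the limit of > 5000 nM in this assay, at which 4 of the 4 values shown sit.

Still open, from the compounds shown here alone, is whether any change on the carbonyl carbon or the aromatic carbon gives a measurable value, and in which direction.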